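Trifluoromethyl for formyl on the aromatic ring: compound 3

The source may hold more compounds than are shown below. What is called first, only, known or untested is meant among the compounds shown, and "the series" means these compounds.

Measured so far:
compound 1, `COc1ccc2c(c1)C(n1ccccc1=O)=CC(C)(C)O2`, 5.99
compound 2, `CC1(C)C=C(n2ccccc2=O)c2cc(C=O)ccc2O1`, 6.14

In a functional assay (trachea) with Rattus norvegicus as the target (a lower number here means a less potent compound, a higher number a more potent compound, by a factor of ten per unit of this negative logarithm), compound 2 holds the higher of the two numbers, but the gap to its nearest neighbour compound 1 is small: the step of a number 0.15 log units higher from compound 1 to compound 2 (within the scatter) does not leave the scatter. The two measured compounds are therefore, for practical purposes, level.

Compound 3, `CC1(C)C=C(n2ccccc2=O)c2cc(C(F)(F)F)ccc2O1`, differs from compound 2 as follows: trifluoromethyl in place of formyl on an aromatic carbon. Among the compounds with values here, the only measured step, a number 0.15 log units higher from compound 1 to compound 2 (within the scatter), concerns a different exchange at this position and is itself within the scatter. Within the data shown here, no measured step involves trifluoromethyl, so there is nothing that shows this change pushing the number in either direction. Among the measured compounds shown here, the one step that bears on the site suggests the position tolerates exchange without a shift beyond the scatter, and on that basis the expected step of a number 0.04 log units lower from compound 2 to compound 3 (within the scatter) is taken as none beyond the scatter. On these data alone, compound 3 is therefore estimated at 6.1, with a range from 5.5 to 6.7, the width reflecting that the trifluoromethyl change is untested here.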

Compound 3, logarithm of the reciprocal of the active concentration, log(1/C): 7.37
Beside the measured number, compound 3's estimate is 1.27 log units below it; measured number outside the range, above it.
By their numbers in this assay, from the lowest: compounds 1 and 2 (each within the scatter of the next); then compound 3.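

In this assay this aromatic carbon no longer reads as a place where exchange leaves the number unmoved: methoxy and formyl sit within the scatter of each other, whereas trifluoromethyl stands clear of both (a number 1.23 log units higher from compound 2 to compound 3 (beyond the scatter); a number 1.38 log units higher from compound 1 to compound 3 (beyond the scatter)). Both steps are large and beyond the scatter, which makes compound 3 the most potent of the three and shows that the group on this carbon can decide the read-out, something the level pair of compound 1 and compound 2 could not reveal. No available evidence accounts for the size of this change, and the data give no reason for it.

On these data alone, whether the gain belongs to trifluoromethyl alone stays open: a nitrile, a chlorine atom, an amine or a carboxylic acid on the same aromatic carbon would show whether other groups join compound 3 or stay level with compound 1 and compound 2. As far as these compounds go, all three compounds also share the rest of the core, so it remains open whether trifluoromethyl keeps this gain when another part of that core is changed.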